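Enediyne Ester Series: Methoxyacetyl Variant Under Estimation

The source may report more compounds than this note shows. Statements on the series, on what has been measured and on what is new or still open speak of the compounds shown alone.

Compound 1: `OC1C#CCCCCC#C/C1=C\c1ccccc1`, 25000 nM
Compound 2: `CC(=O)OC1C#CCCCCC#C/C1=C\c1ccccc1`, 48000 nM

In a functional assay on P388 cells (Mus musculus) for inhibition, read by MTT assay (a lower number here means a stronger inhibitor, a higher number a weaker inhibitor), compound 2 gives 48000 nM, the higher of the two numbers, with compound 1 nearest at a 1.9-fold higher number from compound 1 to compound 2 (0.28 log units; within the scatter). Compound 3 (`COCC(=O)OC1C#CCCCCC#C/C1=C\c1ccccc1`) differs from compound 2 by methoxy in place of hydrogen on a saturated chain carbon bound to a carbonyl carbon. Among the compounds with values here, no measured step touches this change directly; the only step known, a 1.9-fold higher number from compound 1 to compound 2 (0.28 log units; within the scatter), swaps the whole acetyl for hydrogen and stays inside the scatter. On that basis no step beyond the scatter is expected, a 1.0-fold higher number from compound 2 to compound 3 (0.02 log units; within the scatter). Compound 3 is therefore estimated at 50000 nM, with a range from 20000 nM to 125000 nM.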

Compound 3, half-maximal inhibitory concentration: 23000 nM
Beside the measured number, compound 3's estimate is 2.2-fold (0.34 log units) above it, within the range that was stated.
By their numbers in this assay, from the lowest: compounds 3, 1 and 2 (each within the scatter of the next, the first and the last beyond it).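

Within the data shown here, with methoxy in place of hydrogen on a saturated chain carbon bound to a carbonyl carbon, a 2.1-fold lower number from compound 2 to compound 3 (0.32 log units; beyond the scatter) in this assay is the first step here beyond the scatter, though a modest one. Taken as a whole, the change from the parent gives a 1.1-fold lower number from compound 1 to compound 3 (0.04 log units; within the scatter) and so no separation from it. Nothing at hand explains the methoxy step.

Going by these compounds, whether ethoxy, an amine or a carboxylic acid on that same carbon would shift the number further remains open. So does whether this modest step would hold on another core.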